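From compound 3 to compound 4: one added methyl

The source may report more compounds than this note shows. Statements on the series, on what has been measured and on what is new or still open speak of the compounds shown alone.

In a functional assay on MCF7 cells (Homo sapiens) for antiproliferative activity, read by MTT assay, with a stated time of 48 h (a lower number here means a stronger inhibitor, a higher number a weaker inhibitor), compound 3 (`COC(=O)CNC(=O)c1ccc(Oc2nc3ccccc3nc2NC(C)(C)C)cc1`) stands at > 50000 nM and this is a limit of the assay, not a number.

In this assay compound 1 (`COC(=O)[C@H](C)NC(=O)c1ccc(Oc2nc3ccccc3nc2C)cc1`) gives 38400 nM and compound 2 (`CCCCCCCCCCCCNc1nc2ccccc2nc1Oc1ccc(C(=O)N[C@@H](C)C(=O)OC)cc1`) gives 33800 nM and these two values lie within the usual scatter of each other.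

Compound 4 (`COC(=O)[C@H](C)NC(=O)c1ccc(Oc2nc3ccccc3nc2NC(C)(C)C)cc1`) differs from compound 3 by a single change (methyl in place of hydrogen on a saturated chain carbon bound to an amide-type nitrogen and a carbonyl carbon) with methyl in place of hydrogen on a saturated chain carbon bound to an amide-type nitrogen and a carbonyl carbon. This turns (methoxycarbonyl)methyl into 1-(methoxycarbonyl)ethyl.

For the measured compounds named here, no pair of measured compounds isolates this change, and with only a limit for compound 3 the step has no direct measure. Compound 1 at 38400 nM and compound 2 at 33800 nM both carry the 1-(methoxycarbonyl)ethyl group, so a small step towards a stronger inhibitor in this assay is expected, possibly none beyond the scatter. The expected move is an at least 1.2-fold lower number from compound 3 to compound 4 (0.09 log units; that floor lies within the scatter) on this reading. A reading that again reaches the limit also remains likely.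

For compound 4 the estimated value is 40000 nM with an expected range from 20000 nM to 75000 nM in this series.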

Compound 4, half-maximal inhibitory concentration: 38400 nM
Beside the measured number, compound 4's estimate is 1.0-fold (0.02 log units) above it; the measured number falls inside the stated range.
By their numbers in this assay, from the lowest: compounds 2, 1 and 4 (each within the scatter of the next). At a limit, above all of these: compound 3.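

In this assay, for the compounds shown here, adding the methyl on the saturated chain carbon bound to an amide-type nitrogen and a carbonyl carbon, which turns (methoxycarbonyl)methyl into 1-(methoxycarbonyl)ethyl, gives the first step that isolates this change, and it reads as an at least 1.3-fold lower number from compound 3 to compound 4 (0.11 log units; that floor lies within the scatter). Compound 3 stands at a limit of the assay and not at a number, so this step has a floor and no size: the limit of > 50000 nM in this assay, at which 1 of the 4 values shown sits.

With 1-(methoxycarbonyl)ethyl held fixed, the two changes on the core stay inside the scatter in this assay, with a 1.1-fold higher number from compound 2 to compound 4 (0.06 log units; within the scatter) for tert-butyl in place of dodecyl on a nitrogen on an aromatic ring and no change at the digits printed from compound 1 to compound 4 (within the scatter) for (tert-butyl)amino in place of methyl on an aromatic carbon.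

Going by these compounds, the full size of the methyl step stays open, since the floor alone does not separate it from the scatter. Also open, on these data alone, is whether an isopropyl or benzyl group on the same saturated chain carbon, or a carboxylic acid in place of the methyl ester, would move the number beyond the scatter.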